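From methylamino to acetamido: notes on compound 4

This account rests on a few compounds, and the source may have more. Where it says the series, first, only, none or still open, it means among the compounds named here.

Values in a physicochemical assay for solubility, in simulated intestinal fluid, measured as thermodynamic solubility, at pH 6.8; a lower number here means a less soluble compound, a higher number a more soluble compound:
- compound 1 `CN(c1nc2c(c(Nc3ccc(C(F)(F)F)cc3)n1)CCN(c1ncccc1C(F)(F)F)CC2)C1CCCNC1`: 211 ug/mL
- compound 2 `FC(F)(F)c1ccc(Nc2nc(N3CCN(C4CCC4)CC3)nc3c2CCN(c2ncccc2C(F)(F)F)CC3)cc1`: 2 ug/mL
- compound 3 `CNC1CCN(c2nc3c(c(Nc4ccc(C(F)(F)F)cc4)n2)CCN(c2ncccc2C(F)(F)F)CC3)C1`: 233 ug/mL

Compound 3 and compound 1 sit level within the scatter, a 1.1-fold higher number from compound 1 to compound 3 (0.04 log units; within the scatter). Compound 3 stands far clear of compound 2, a 120-fold higher number from compound 2 to compound 3 (2.07 log units; beyond the scatter).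

Compound 4 `CC(=O)NC1CCN(c2nc3c(c(Nc4ccc(C(F)(F)F)cc4)n2)CCN(c2ncccc2C(F)(F)F)CC3)C1` carries 3-acetamidopyrrolidin-1-yl, with acetyl in place of methyl on an amine nitrogen. For the measured compounds named here, no measured step changes that nitrogen alone. All three exchange the whole group on an aromatic carbon, so they bear on the change only indirectly. They do show that this group can matter a great deal, a 110-fold lower number from compound 1 to compound 2 (2.02 log units; beyond the scatter), or not at all beyond the scatter. Compound 1 and compound 3 both hold a secondary amine in that group, whereas compound 2 and compound 4 do not. On three compounds this is a weak guide, but it points downward. The estimate is a 16-fold lower number from compound 3 to compound 4 (1.19 log units; beyond the scatter), an expected large fall in this assay. For compound 4 the expected value is 15 ug/mL, with an expected range of 3 ug/mL to 80 ug/mL.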

Compound 4, solubility: 19 ug/mL
Estimate against measurement, compound 4: 1.3-fold (0.10 log units) below; the range from low to high includes it.
By their numbers in this assay, from the lowest: compound 2; then compound 4; then compounds 1 and 3 (each within the scatter of the next).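

In this assay, the change on this amine nitrogen now has a direct reading: acetyl in place of methyl, with nothing else altered, gives a clear fall (a 12-fold lower number from compound 3 to compound 4 (1.09 log units; beyond the scatter)). Compound 4 also stands apart from both other neighbours (an 11-fold lower number from compound 1 to compound 4 (1.05 log units; beyond the scatter); a 9.5-fold higher number from compound 2 to compound 4 (0.98 log units; beyond the scatter)), so the two compounds with a secondary amine in this group sit level, while the two without one, compound 2 and compound 4, do not. No accompanying measurement speaks to the origin of this fall.

Still open, from the compounds shown here alone, is whether the fall tracks the acetyl itself or the loss of the secondary amine, which dimethylamino, a primary amine or methanesulfonamido in place of methylamino could help separate. Also open, going by these compounds, is whether the same exchange would read alike on the methyl(piperidin-3-yl)amino group of compound 1.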